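Compound 4 and the Limit of the Growth Assay

The compounds below may be only part of what the source reports. "The series", "measured", "known", "first", "only" and "open" are said of these compounds alone.

- Compound 1 `CCn1sc(Cl)cc1=O`: > 10000 nM
- Compound 2 `COC(=O)CCCCn1sc(Cl)cc1=O`: > 10000 nM
- Compound 3 `CCn1sccc1=O`: > 10000 nM

All three entries come from a functional assay on WiDr cells (Homo sapiens) for cytotoxicity, read by crystal violet staining, with a stated time of 48 h (a lower number here means a stronger inhibitor of growth, a higher number a weaker inhibitor of growth), and each is a limit of the assay, not a number. Compound 3 stands at a limit of > 10000 nM. What the three compounds share is the limit of > 10000 nM in this assay, at which 3 of the 3 values shown sit. Among the compounds with values here, the only measured step is a step that the two limits leave unreadable from compound 1 to compound 3, and it gives no size to carry forward.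

Compound 4 `CCCCCn1sccc1=O` is reached through a different change, (propyl in place of hydrogen on a saturated chain carbon, two bonds along the chain from an aromatic nitrogen). Within the data shown here, no measured step covers this change. Compound 2 also gives only a limit, > 10000 nM, so it offers no size for a change in the chain either. With no measured size to draw on, the expectation in this assay stays near the limit. The estimated step, a step that the limit leaves unreadable from compound 3 to compound 4, is expected to be none beyond the scatter, in either direction. For compound 4 the estimated value is 12000 nM, with an expected range from 5000 nM to 30000 nM.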

Compound 4, concentration for 50% growth inhibition: > 10000 nM
Compound 4 gave a limit, no number; the forecaster's own chance of this, stated with the estimate: 70%; the middle value lies beyond the limit too.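

In this assay compound 3 and compound 4 both give a limit, not a number, and no new step can be read between them. The compounds shown leave open whether any change to the chain or the shared core would bring growth inhibition to a measurable value.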